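The compounds below may be only part of what the source reports. "The series", "measured", "known", "first", "only" and "open" are said of these compounds alone.

In a functional assay on A549 cells (Homo sapiens) for antiproliferative activity, read by MTT assay, with a stated time of 72 h (on this read-out higher numbers stand for weaker inhibition and lower numbers for stronger inhibition), compound 1 (`C=CC(=O)Nc1cccc(Oc2nc(Nc3cccc(OC)c3)nc3c2CSCC3)c1`), with vinyl on a carbonyl carbon, gives 10100 nM on the shared core. With but-1-en-1-yl at that place, compound 2 (`CC/C=C/C(=O)Nc1cccc(Oc2nc(Nc3cccc(OC)c3)nc3c2CSCC3)c1`) gives 17200 nM in this assay as well. With 2-methylprop-1-en-1-yl there, compound 3 (`COc1cccc(Nc2nc3c(c(Oc4cccc(NC(=O)C=C(C)C)c4)n2)CSCC3)c1`) gives 19800 nM in this assay too. Compound 3 stands within the scatter of both other compounds, as a 2.0-fold higher number from compound 1 to compound 3 (0.29 log units; within the scatter) and a 1.2-fold higher number from compound 2 to compound 3 (0.06 log units; within the scatter) show.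

Compound 4 (`COc1cccc(Nc2nc3c(c(Oc4cccc(NC(=O)/C=C/C(C)C)c4)n2)CSCC3)c1`) has not yet been measured. It differs from compound 3 by 3-methylbut-1-en-1-yl in place of 2-methylprop-1-en-1-yl on a carbonyl carbon in that 3-methylbut-1-en-1-yl takes the place of 2-methylprop-1-en-1-yl on a carbonyl carbon. Among the measured compounds shown here, all the measured steps bear on this change, since each one swaps the group at that same place. Besides the two already given, there is a 1.7-fold higher number from compound 1 to compound 2 (0.23 log units; within the scatter) and none of the three leaves the scatter. No step beyond the scatter is therefore expected in this assay for this change, and no direction can be expected from these data. The expected step is a 1.1-fold lower number from compound 3 to compound 4 (0.04 log units; within the scatter) and would stay within the scatter. For compound 4 the estimated value is 18000 nM in the middle, with an expected range from 9000 nM to 36000 nM for repeated measurements.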

Compound 4, half-maximal inhibitory concentration: 25300 nM
Estimate against measurement, compound 4: 1.4-fold (0.15 log units) below; low and high end bracket the measured number.
By their numbers in this assay, from the lowest: compounds 1, 2, 3 and 4 (each within the scatter of the next, the first and the last beyond it).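

In this assay, the step of a 1.3-fold higher number from compound 3 to compound 4 (0.11 log units; within the scatter) and the step of a 1.5-fold higher number from compound 2 to compound 4 (0.17 log units; within the scatter) leave 3-methylbut-1-en-1-yl indistinguishable from the other two substituted alkenyl groups at this place on the carbonyl carbon. Among the compounds shown here, the step of a 2.5-fold higher number from compound 1 to compound 4 (0.40 log units; beyond the scatter), however, is the first at this position to leave the scatter, so a modest separation now appears between vinyl and 3-methylbut-1-en-1-yl, with the higher number standing for weaker inhibition; compounds 2 and 3 stay within the scatter of compound 1, so this separation rests on compound 4 alone. No measurement offered here accounts for this separation.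

Every group shown at this place is an open hydrocarbon chain with one double bond, so it remains open how a saturated chain, a longer chain, or a chain ending in an amine or a carboxylic acid would read in this assay. From the compounds shown here alone, whether the separation between compound 1 and compound 4 would also appear on other cells remains open too, as all four values come from this single read-out.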